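The source may report more compounds than this note shows. Statements on the series, on what has been measured and on what is new or still open speak of the compounds shown alone.

Measured so far in an ADME assay on PANC-1 cells (Homo sapiens) for cytotoxicity, read by sulforhodamine B assay, with a stated time of 48 h, tested at 10 uM; a lower number here means less inhibition, a higher number more inhibition at the concentration tested (going by the name of the read-out): compound 1 `COc1nc2ccc(Br)cc2cc1C(c1ccccc1)n1cc(-c2ccc(Br)cc2)nn1` gives 10.4%; compound 2 `COc1nc2ccc(Br)cc2cc1C(c1ccccc1)n1cc(-c2ccccc2)nn1` gives 30.1%; compound 3 `COc1nc2ccc(Br)cc2cc1C(c1ccccc1)n1cc(-c2ccccc2F)nn1` gives 14.7%.

Compound 2 stands highest of the three, with compound 3 nearest and compound 1 furthest. Compound 4 `CCCCCCCCc1cn(C(c2ccccc2)c2cc3cc(Br)ccc3nc2OC)nn1` is the unmeasured analogue; it differs from compound 2 as follows: octyl in place of phenyl on an aromatic carbon. For the measured compounds named here, no measured step swaps the ring for a chain, so none bears directly on this change. The steps that alter this same position, a number 19.7 percentage points higher from compound 1 to compound 2 (beyond the scatter) and a number 15.4 percentage points lower from compound 2 to compound 3 (beyond the scatter), were modest and both sides of compound 2 sit lower, so a modest downward step is expected for compound 4, a number 12.1 percentage points lower from compound 2 to compound 4 (beyond the scatter). Compound 4 is therefore estimated at 18%, within 5% to 40%.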

Compound 4, a percentage reported as inhibition, at one concentration (the size of the read-out at that concentration, not a potency): 12.1%
Estimate against measurement, compound 4: 5.9 percentage points above, within the range that was stated.
By their numbers in this assay, from the lowest: compounds 1, 4 and 3 (each within the scatter of the next); then compound 2.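

In this assay, swapping the ring for a chain at this aromatic carbon gives a number 18 percentage points lower from compound 2 to compound 4 (beyond the scatter), so the higher reading of the unsubstituted phenyl is not kept by octyl. Octyl cannot be told apart from either substituted phenyl, with a number 2.6 percentage points lower from compound 3 to compound 4 (within the scatter) and a number 1.7 percentage points higher from compound 1 to compound 4 (within the scatter), so among these compounds the lower level does not depend on an aromatic ring at this position. Nothing available explains this result. Still open, as far as these compounds go, is whether a shorter chain such as butyl, or an octyl chain ending in an amine or a carboxylic acid, would stay at this lower level or reach that of compound 2.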